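Adding a methyl to the acid of compound 3

A few compounds are considered here, and "the series" means these few. Any claim that something is new, unique, unknown or untested is made for them only; others in the source may bear on it.

In a functional assay on HEL cells (Homo sapiens) (a lower number here means that less compound is tolerated, a higher number that more compound is tolerated), compound 1 (`CCOC(=O)CNC(=O)NC1=CS(=O)(=O)O[C@@]12[C@@H](CO[Si](C)(C)C(C)(C)C)O[C@@H](n1cc(C)c(=O)n(C)c1=O)[C@@H]2O[Si](C)(C)C(C)(C)C`) gives 13000 nM as its half-maximal cytotoxic concentration. Compound 2 (`COC(=O)NC1=CS(=O)(=O)O[C@@]12[C@@H](CO[Si](C)(C)C(C)(C)C)O[C@@H](n1cc(C)c(=O)n(C)c1=O)[C@@H]2O[Si](C)(C)C(C)(C)C`) is recorded only as the limit > 200000 nM and not as an exact number. Among the compounds with values here, compound 3 (`Cc1cn([C@@H]2O[C@H](CO[Si](C)(C)C(C)(C)C)[C@@]3(OS(=O)(=O)C=C3NCC(=O)C(=O)O)[C@H]2O[Si](C)(C)C(C)(C)C)c(=O)n(C)c1=O`) gives 146000 nM and so holds the higher of the two exact numbers, the gap being an 11-fold higher number from compound 1 to compound 3 (1.05 log units; beyond the scatter) and the only firm comparison available. Against the limit, little can be said (an at least 1.3-fold lower number from compound 2 to compound 3 (0.13 log units; that floor lies within the scatter)).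

Compound 4 (`COC(=O)C(=O)CNC1=CS(=O)(=O)O[C@@]12[C@@H](CO[Si](C)(C)C(C)(C)C)O[C@@H](n1cc(C)c(=O)n(C)c1=O)[C@@H]2O[Si](C)(C)C(C)(C)C`) has methyl in place of hydrogen on an oxygen next to a carbonyl group, so carboxycarbonyl becomes (methoxycarbonyl)carbonyl (methyl in place of hydrogen on an oxygen next to a carbonyl group). Within the data shown here, no measured step makes this exact swap. The closest guide is compound 1, an ethoxycarbonyl compound with the lower number (13000 nM in this assay), which suggests a modest move downward. Compound 2 goes against this, since it also carries a methoxycarbonyl group yet sits at its limit. The expected change is a 2.4-fold lower number from compound 3 to compound 4 (0.39 log units; beyond the scatter) and remains uncertain. Compound 4 is estimated at 60000 nM with an expected range of 15000 nM to 200000 nM in this test.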

Compound 4, half-maximal cytotoxic concentration: > 200000 nM
Compound 4 gave a limit, no number (the forecaster's own chance of this, stated with the estimate: 25%); middle value at least 3.3-fold (0.52 log units) from the limit.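

Compound 4 is recorded only as the limit > 200000 nM, which is not an exact number. In this assay, putting methyl in place of hydrogen on this oxygen therefore gives no sign of a lower number, the step being an at least 1.3-fold higher number from compound 3 to compound 4 (0.13 log units; that floor lies within the scatter), so the free carboxycarbonyl acid is not needed for a high number here. The methyl ester also keeps a wide gap to the urea-linked ethoxycarbonyl compound, an at least 15-fold higher number from compound 1 to compound 4 (1.18 log units; beyond the scatter), while the step between compound 2 and compound 4 cannot be read, as both values are limits.

On these data alone, the real size of the methyl step stays unknown because compound 4 sits at a limit: the limit of > 200000 nM in this assay, at which 2 of the 4 values shown sit. Whether an ethyl ester or a primary amide at this carbonyl would also reach this limit remains open.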